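The compounds below may be only part of what the source reports. "The series", "measured", "known", "first", "only" and "open" are said of these compounds alone.

Measured so far in an ADME assay on microsomes from liver (Mus musculus) for metabolic stability, read by LC-MS, with a stated time of 10 min, tested at 0.5 uM; a lower number here means that less of the compound is left, a higher number that more of the compound is left:

compound 1, `CN1CCN(CCCN(C[C@H]2Cc3ccccc3CN2)[C@H]2CCCc3cccnc32)CC1`: 53%
compound 2, `c1cnc(CN(CCCN2CCNCC2)[C@H]2CCCc3cccnc32)nc1`: 78%
compound 3, `CCN1CCN(CCCN(C[C@H]2Cc3ccccc3CN2)[C@H]2CCCc3cccnc32)CC1`: 19%

Among these three, compound 1 stands second highest. Compound 2 lies above it beyond the scatter, and compound 3 lies below it, also beyond the scatter. Compound 4, `c1ccc2c(c1)CN[C@@H](CN(CCCN1CCNCC1)[C@H]1CCCc3cccnc31)C2`, is the next compound to be measured in this assay. It differs from compound 1 in one place: hydrogen in place of methyl on an amine nitrogen in a ring.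

Among the measured compounds shown here, one measured step bears on this change. Going from compound 1 to compound 3, a methyl replaced a hydrogen on a saturated chain carbon bound to the same amine nitrogen in a ring, and the value fell: a number 34 percentage points lower from compound 1 to compound 3 (beyond the scatter). The step from compound 1 to compound 4 removes carbon from that nitrogen rather than adding it, so it points in the opposite direction. Compound 2 also carries the unsubstituted ring nitrogen and gives the highest value of the three, though it differs from compound 1 in more than one place, so only its value can be read. Taken together, a rise beyond the scatter is expected for compound 4, a number 15 percentage points higher from compound 1 to compound 4 (beyond the scatter), giving an estimated 68%, with a range from 50% to 85%.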

Compound 4, percent of the compound remaining: 92%
For compound 4 the middle estimate is 24 percentage points below the measured one, and the stated range ends below it.
By their numbers in this assay, from the lowest: compound 3; then compound 1; then compound 2; then compound 4.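

In this assay, the group on the ring nitrogen can now be read as a series of three: going from 4-methylpiperazin-1-yl to piperazin-1-yl gives a number 39 percentage points higher from compound 1 to compound 4 (beyond the scatter) and means a large rise, and hydrogen in place of ethyl gives a number 73 percentage points higher from compound 3 to compound 4 (beyond the scatter) and means a larger one still. Across compound 4, compound 1 and compound 3, then, the number falls with each added carbon on this nitrogen, so the fall seen with ethyl was part of a trend that already starts at methyl. With piperazin-1-yl present in both compounds, 1,2,3,4-tetrahydroisoquinolin-3-yl in place of pyrimidin-2-yl gives a number 14 percentage points higher from compound 2 to compound 4 (beyond the scatter) and is only a modest step, which makes the change on the ring nitrogen the larger of the two effects seen here, and no measurement at hand gives a reason for any of these steps.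

On these data alone, whether a propyl chain or an acetyl group on this nitrogen would continue the fall remains open. As far as these compounds go, it is also open whether the order of hydrogen, methyl and ethyl holds when pyrimidin-2-yl replaces 1,2,3,4-tetrahydroisoquinolin-3-yl.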